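This account rests on a few compounds, and the source may have more. Where it says the series, first, only, none or still open, it means among the compounds named here.

Compound 2, `Cc1ccc2occ(C3N=C(c4ccccc4)SS3)c(=O)c2c1`, is measured in a functional assay on OVCAR-3 cells (Homo sapiens) for inhibition, read by sulforhodamine B assay, with a stated time of 48 h (on this read-out lower numbers stand for stronger inhibition and higher numbers for weaker inhibition), at 93700 nM. Of the two numbers in this set, compound 2 carries the higher one; compound 1, `O=c1c(C2N=C(c3ccccc3)SS2)coc2cc(Cl)ccc12`, gives 10500 nM in this assay, and the gap between the two lies beyond the scatter. Compound 3, `O=c1c(C(=S)Nc2ccccc2)coc2cc(Cl)c(Cl)cc12`, returns only a limit in this assay, > 100000 nM, which is the limit of > 100000 nM in this assay, at which 1 of the 3 values shown sits, and not a number. Compound 4, `O=c1c(C2N=C(c3ccccc3)SS2)coc2ccc(Cl)cc12`, has not yet been measured in this assay. It differs from compound 2 in one place: chloro in place of methyl on an aromatic carbon. Among the measured compounds shown here, no pair of measured compounds differing in a single place is available, so the size of this step has no measured anchor in the set. Because compound 1 also carries a chloro on its core and gives 10500 nM in this assay, the expected step is one toward a lower number, a 3.1-fold lower number from compound 2 to compound 4 (0.49 log units; beyond the scatter), of a size beyond the scatter. The estimate for compound 4 in this assay is 30000 nM, between 8000 nM and 100000 nM.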

Compound 4, half-maximal inhibitory concentration: 66500 nM
Compound 4: middle estimate off by 2.2-fold (0.35 log units), on the low side, within the range that was stated.
By their numbers in this assay, from the lowest: compound 1; then compounds 4 and 2 (each within the scatter of the next). At a limit, above all of these: compound 3.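

In this assay, among the compounds shown here, exchanging methyl for chloro on this aromatic carbon gives a 1.4-fold lower number from compound 2 to compound 4 (0.15 log units; within the scatter), the first step in the set between measured compounds that differ in one place. This gives the series a measured anchor: at this position, on this read-out, methyl and chloro are not separated. Nothing measured here bears on the cause of this step.

The compounds shown carry only methyl and chloro at this position, so it stays open whether a methoxy group, an amine or a carboxylic acid there would leave the number within the scatter or move it beyond. For the compounds shown here, they also offer no single-place step anywhere else on the molecule, so this one step cannot yet be set against changes at other positions.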